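A Single Methyl Added to Compound 2

A few compounds are considered here, and "the series" means these few. Any claim that something is new, unique, unknown or untested is made for them only; others in the source may bear on it.

In a functional assay on MDA-MB-231 cells (Homo sapiens) for cytotoxicity, read by MTT assay, with a stated time of 96 h (a higher number here means a weaker inhibitor, a lower number a stronger inhibitor), compound 1 `CC[C@H](NC)C(=O)N[C@@H]1C(=O)N2[C@@H](CC[C@@H]1CN)CC[C@H]2C(=O)NC(c1ccccc1)c1ccccc1` gives 542 nM, while compound 2 `CC[C@H](N)C(=O)N[C@@H]1C(=O)N2[C@@H](CC[C@@H]1CCNC(=O)NCc1ccccc1)CC[C@H]2C(=O)NC(c1ccccc1)c1ccccc1` gives 10800 nM, the higher of the two numbers and therefore the weaker result. Compound 3 `CC[C@H](NC)C(=O)N[C@@H]1C(=O)N2[C@@H](CC[C@@H]1CCNC(=O)NCc1ccccc1)CC[C@H]2C(=O)NC(c1ccccc1)c1ccccc1` differs from compound 2 in one place: methyl in place of hydrogen on an amine nitrogen. Compound 1 also carries the methylamino group, with its 542 nM, but it differs elsewhere too, so it cannot isolate this change. In this assay a moderate fall beyond the scatter is expected, and the estimated step is a 3.6-fold lower number from compound 2 to compound 3 (0.56 log units; beyond the scatter). The expected value for compound 3 is 3000 nM, within an estimated range of 800 nM to 11000 nM.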

Compound 3, half-maximal inhibitory concentration: 1200 nM
Beside the measured number, compound 3's estimate is 2.5-fold (0.40 log units) above it; low and high end bracket the measured number.
By their numbers in this assay, from the lowest: compound 1; then compound 3; then compound 2.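

Going by these compounds alone, compound 3 isolates this change for the first time: in this assay methyl in place of hydrogen on the amine nitrogen gives a 9.0-fold lower number from compound 2 to compound 3 (0.95 log units; beyond the scatter) with the rest of the molecule unchanged. With the methylamino group present in both compounds, ((benzylcarbamoyl)amino)methyl in place of amino gives a 2.2-fold higher number from compound 1 to compound 3 (0.35 log units; beyond the scatter) as a separate, second step. No measurement here accounts for either step. From the compounds shown here alone, whether an ethyl group or a second methyl on this nitrogen would lower the number further remains open. So does the size of the methyl step when the amino group of compound 1 is present.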